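The source may hold more compounds than are shown below. What is called first, only, known or untested is meant among the compounds shown, and "the series" means these compounds.

Measured compounds:
compound 1 `O=C1O[C@@H](CN2CCCCC2)CN1c1ccc(-n2cc(-c3ccccn3)cn2)c(F)c1` with 3.1
compound 2 `O=C1CCC(=O)N1C[C@H]1CN(c2ccc(-n3cc(-c4ccccn4)cn3)c(F)c2)C(=O)O1` with 1.58

These two compounds share one core and differ in a single group. In a physicochemical assay for lipophilicity, read by HPLC, measured as octanol-water partition (a lower number here means a more polar compound, a higher number a more lipophilic compound), compound 1 gives 3.1, and compound 2 gives 1.58. Within the data shown here, the one step seen so far, a number 1.52 log units lower from compound 1 to compound 2 (beyond the scatter), is a large drop that followed an exchange of a whole ring at the saturated chain carbon. Compound 2 therefore stands as the lower of the two numbers, with compound 1 a good way above it.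

Compound 3 `O=C1CSC(=O)N1C[C@H]1CN(c2ccc(-n3cc(-c4ccccn4)cn3)c(F)c2)C(=O)O1` is not yet measured. Its difference from compound 2 is 2,4-dioxo-1,3-thiazolidin-3-yl in place of 2,5-dioxopyrrolidin-1-yl on a saturated chain carbon bound to a saturated ring carbon. The ring that enters has the same number of heavy atoms as the one that leaves, again with two carbonyls, and one ring carbon is replaced by a ring sulfur, which adds one hydrogen-bond acceptor. The measured step from compound 1 to compound 2 concerned a quite different exchange, a basic amine ring for an imide, so it gives no direct guide here. Since the two imide rings are so alike in size and count, the step of a number 0.08 log units lower from compound 2 to compound 3 (within the scatter) is expected to stay within the usual scatter, in no clear direction. Compound 3 is estimated at 1.5, likely between 1 and 2.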

Compound 3, partition coefficient: 2.18
For compound 3 the middle estimate is 0.68 log units below the measured one, and the stated range ends below it.
By their numbers in this assay, from the lowest: compound 2; then compound 3; then compound 1.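

In this assay, the exchange on a saturated chain carbon bound to a saturated ring carbon gives a number 0.60 log units higher from compound 2 to compound 3 (beyond the scatter), so this position responds even when the entering and leaving rings have the same number of heavy atoms and the same number of double bonds outside aromatic rings. The earlier pair showed only the large effect of replacing piperidin-1-yl with a very different ring, whereas here 2,4-dioxo-1,3-thiazolidin-3-yl differs from 2,5-dioxopyrrolidin-1-yl by one ring sulfur in place of one ring carbon, and the reading still moves beyond the scatter; against piperidin-1-yl, the same ring gives a number 0.92 log units lower from compound 1 to compound 3 (beyond the scatter), so the two rings with two carbonyls do not stand at one common level. Nothing available here accounts for the size or direction of either step.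

Among these compounds, with only three groups at this place, it remains open where a morpholin-4-yl ring, an open-chain acetamide or a carboxylic acid on the same chain carbon would fall on this scale. Going by these compounds, it is also open whether 2,4-dioxo-1,3-thiazolidin-3-yl would give a similar step on a longer chain.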